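The source may report more compounds than this note shows. Statements on the series, on what has been measured and on what is new or still open speak of the compounds shown alone.

Compound 3 `COc1nc(N)nc2c1c(-c1ccoc1)cn2[C@@H]1O[C@H](CO)[C@@H](O)[C@H]1O` carries furan-3-yl on the shared core together with the amino group. In a functional assay on A549 cells (Homo sapiens), read by MTT assay, with a stated time of 72 h (on this read-out higher numbers stand for weaker inhibition and lower numbers for stronger inhibition), compound 3 gives only a limit, > 20000 nM. Compound 1 `COc1nc(N)nc2c1c(-c1ccccc1)cn2[C@@H]1O[C@H](CO)[C@@H](O)[C@H]1O`, with phenyl at the same aromatic carbon, also gives only a limit in this assay, > 20000 nM. The step that the two limits leave unreadable from compound 1 to compound 3 is thus unreadable, both ends resting at the limit of > 20000 nM in this assay, at which 2 of the 3 values shown sit. For the measured compounds named here, compound 2 `COc1ncnc2c1c(-c1ccco1)cn2[C@@H]1O[C@H](CO)[C@@H](O)[C@H]1O`, which carries furan-2-yl and lacks the amino group, gives 30 nM in this assay; no single-change step joins it to compound 3, so its value shows only that this variant is measurable.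

Compound 4 `COc1nc(N)nc2c1c(-c1ccco1)cn2[C@@H]1O[C@H](CO)[C@@H](O)[C@H]1O` is to be measured in this assay. The change is furan-2-yl in place of furan-3-yl on an aromatic carbon. Going by the values given here, the one measured step on a change at this carbon, a step that the two limits leave unreadable from compound 1 to compound 3, carries no readable size, and the compounds bearing the amino group have given no number so far. The step expected is an at least 1.3-fold lower number from compound 3 to compound 4 (0.12 log units; that floor lies within the scatter). Compound 4 is estimated at 15000 nM, with a range from 2000 nM to 40000 nM, and a limit is the likelier outcome.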

Compound 4, half-maximal inhibitory concentration: > 20000 nM
Compound 4: no number, only a limit (the forecaster's own chance of this, stated with the estimate: 55%); middle value at least 1.3-fold (0.12 log units) from the limit.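

In this assay, compound 4 gives only a limit, > 20000 nM. For the compounds shown here, with furan-2-yl held constant, amino in place of hydrogen on an aromatic carbon gives the first readable step, an at least 660-fold higher number from compound 2 to compound 4 (2.82 log units; beyond the scatter), which places the large change at the amino position and not at the aryl position. The steps among the amino-bearing compounds cannot be read, so phenyl, furan-3-yl and furan-2-yl cannot be ranked on this carbon while all three rest at the same limit: the limit of > 20000 nM in this assay, at which 3 of the 4 values shown sit.

Phenyl and furan-3-yl on the core without the amino group remain open, and only such pairs could show whether the aryl change matters there. Also open, on these data alone, is whether a methyl group or a chlorine atom in place of the amino group keeps a measurable value in this assay.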